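The source may hold more compounds than are shown below. What is called first, only, known or untested is meant among the compounds shown, and "the series" means these compounds.

Three compounds of this series have been run through an ADME assay on the whole organism (Rattus norvegicus, strain Wistar Han) for metabolic stability; a lower number here means slower removal, a higher number faster removal of the compound. Compound 1, `CCn1c(-c2cnc(C)nc2)nc2c(N[C@H]3CCN(C(=O)c4cocn4)C3)ncnc21`, gives 150 mL/min/kg. Compound 2, `CCC(=O)N1CC[C@H](Oc2ncnc3c2nc(-c2cnc(C)nc2)n3CC)C1`, gives 31 mL/min/kg. Compound 3, `CCn1c(-c2ccc(C(F)(F)F)nc2)nc2c(O[C@H]3CCN(C(=O)C4CC4)C3)ncnc21`, gives 240 mL/min/kg. Among these three numbers compound 2 stands lowest: compound 1 lies well above it, beyond the usual scatter, and compound 3 lies further above still, also beyond the scatter. Compound 2 is therefore the one with the slowest removal of the three.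

The account now follows the step from compound 2 to compound 4, `CCn1c(-c2cnc(C)nc2)nc2c(O[C@H]3CCN(C(=O)C4CCOC4)C3)ncnc21`, which has not yet been measured in this assay. The two structures differ in one place: oxolan-3-yl in place of ethyl on a carbonyl carbon. For the measured compounds named here, no pair of measured compounds in the set differs by this same change, so there is no measured step to lean on. The author expects the step of a 1.1-fold higher number from compound 2 to compound 4 (0.05 log units; within the scatter) to be small, at most modest and, if anything, upward, but not clearly beyond the scatter. On that basis compound 4 is estimated to give about 35 mL/min/kg in this assay, with a range from 14 mL/min/kg to 90 mL/min/kg.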

Compound 4, clearance: 12 mL/min/kg
The estimate for compound 4 lay 2.9-fold (0.46 log units) above the measured number; the measured number lies below the stated range.
By their numbers in this assay, from the lowest: compound 4; then compound 2; then compounds 1 and 3 (each within the scatter of the next).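

In this assay, putting oxolan-3-yl in place of ethyl on the carbonyl carbon, whose other neighbour is an amide-type nitrogen in a ring, gives a 2.6-fold lower number from compound 2 to compound 4 (0.41 log units; beyond the scatter). For the compounds shown here, the earlier compounds offered no pair differing in one place, so this is the first sign that the group at this position alone can shift the number beyond the scatter, and that going from the ethyl group's two carbon atoms to a five-membered ring with one oxygen does not raise it here. Nothing measured in this set explains the direction of the step.

The compounds shown leave open whether the step goes with the ring itself or with its oxygen, and a cyclopentyl group on the same carbonyl carbon would set those two apart. They also leave open whether the same change would give a step of similar size in a compound that differs elsewhere, such as compound 3 with its trifluoromethyl group, which carries a cyclopropyl group on this carbonyl carbon.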